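Swapping the meta substituent: from trifluoromethyl to methoxy

This account rests on a few compounds, and the source may have more. Where it says the series, first, only, none or still open, it means among the compounds named here.

Measured so far:
- compound 1, `Cc1cccc(C(=O)Nc2cccc(/C=C/C(=O)c3nc4ccccc4[nH]3)c2)c1`: 5590 nM
- compound 2, `O=C(Nc1cccc(/C=C/C(=O)c2nc3ccccc3[nH]2)c1)c1cccc(C(F)(F)F)c1`: 21500 nM

In a functional assay on MCF7 cells (Homo sapiens) for antiproliferative activity, read by MTT assay, with a stated time of 48 h (a lower number here means a stronger inhibitor, a higher number a weaker inhibitor), compound 2 gives the highest of the two numbers recorded, that is the weaker of the two inhibitors; its nearest neighbour is compound 1 with 5590 nM. Going by the values given here, the one measured step shows what a change at this position can do: a 3.8-fold higher number from compound 1 to compound 2 (0.59 log units; beyond the scatter).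

Compound 3, `COc1cccc(C(=O)Nc2cccc(/C=C/C(=O)c3nc4ccccc4[nH]3)c2)c1`, has not yet been measured. It differs from compound 2 in one place: methoxy in place of trifluoromethyl on an aromatic carbon. The step from compound 1 to compound 2 is the only one that bears on this, and it points to the group at this position mattering well beyond the scatter. Since methoxy is closer in size to the methyl of compound 1 than to the trifluoromethyl of compound 2, compound 3 is expected to move back toward the number of compound 1, giving a step of a 3.1-fold lower number from compound 2 to compound 3 (0.49 log units; beyond the scatter) in this assay. The estimate for compound 3 is therefore 7000 nM, within a range of 2500 nM to 20000 nM.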

Compound 3, half-maximal inhibitory concentration: 17800 nM
Compound 3: the middle estimate sits 2.5-fold (0.41 log units) below what was measured, and the stated range covers the measured number.
By their numbers in this assay, from the lowest: compound 1; then compounds 3 and 2 (each within the scatter of the next).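

In this assay the change from trifluoromethyl to methoxy gives a 1.2-fold lower number from compound 2 to compound 3 (0.08 log units; within the scatter) and so makes no readable difference at this position, even though these are two different groups. Against methyl, methoxy gives a 3.2-fold higher number from compound 1 to compound 3 (0.50 log units; beyond the scatter) and trifluoromethyl gives a 3.8-fold higher number from compound 1 to compound 2 (0.59 log units; beyond the scatter), so compound 1 is the strongest inhibitor of the three, and the earlier step no longer reads as something peculiar to trifluoromethyl, since a second replacement of methyl shows a step beyond the scatter as well. Why methyl stands apart from the other two groups cannot be said, as nothing available here speaks to a cause.

Going by these compounds alone, with only three groups at this position, it remains open whether methyl is close to the best choice here or merely the best of these three. A longer chain such as ethyl, a single chlorine atom, a hydroxyl or an amine in the same place would show whether any other group can match compound 1 or improve on it, and whether compound 2 and compound 3 mark a common level for replacements of methyl.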